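A few compounds are considered here, and "the series" means these few. Any claim that something is new, unique, unknown or untested is made for them only; others in the source may bear on it.

Measured so far:
- compound 1, `Cc1ccnc(/C(N)=N/NC(=S)N2CCN(c3ccccn3)CC2)c1`: 21%
- compound 2, `Cc1cccc(/C(N)=N/NC(=S)N2CCCC2)n1`: 17.4%
- compound 3, `N/C(=N\NC(=S)N1CCCC1)c1ccccn1`: 45.9%

In a functional assay on MCF7 cells (Homo sapiens) for cytotoxicity, read by MTT assay, with a stated time of 72 h, tested at 1 uM (on this read-out higher numbers stand for more inhibition of growth at the one concentration tested and lower numbers for less inhibition of growth), compound 3 gives the highest of the three numbers. Compound 1 and compound 2 lie within the scatter of each other; the difference between their two cores is not broken down here. Compound 2 and compound 3 differ by hydrogen in place of methyl on an aromatic carbon, and that single change gave a number 28.5 percentage points higher from compound 2 to compound 3 (beyond the scatter).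

Compound 4, `N/C(=N\NC(=S)N1CCN(c2ccccn2)CC1)c1ccccn1`, is not yet measured. It differs from compound 1 by hydrogen in place of methyl on an aromatic carbon. Among the compounds with values here, the change is of the same kind as the one from compound 2 to compound 3, but the place is not the same: there the hydrogen sits "next to the ring nitrogen; meta to a large group", here it is "meta to a large group; opposite the ring nitrogen". Within the data shown here, the step from compound 1 to compound 4 is therefore expected to be smaller and less certain than the earlier one, and is estimated at a number 17 percentage points higher from compound 1 to compound 4 (beyond the scatter), resting on the single precedent a number 28.5 percentage points higher from compound 2 to compound 3 (beyond the scatter). Compound 4 is expected to give about 38% in this assay, with a plausible range from 20% to 58%.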

Compound 4, percent growth inhibition at one concentration: 36%
Compound 4: middle estimate off by 2 percentage points, on the high side, within the range that was stated.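

In this assay, hydrogen in place of methyl gives a number 15 percentage points higher from compound 1 to compound 4 (beyond the scatter), so the direction of the earlier step carries over to the core of compound 1. Within the data shown here, the two steps cannot be told apart in size: the same change on two cores in this assay, a number 28.5 percentage points higher (beyond the scatter) from compound 2 to compound 3 and a number 15 percentage points higher (beyond the scatter) from compound 1 to compound 4, 13.5 percentage points apart, within the scatter of two such steps This rests on only two cores, and the methyl leaves from a different place in each step (meta to a large group and opposite the ring nitrogen in the new one), so the effect of core cannot be separated from the effect of place, and no fixed size for the gain can be claimed.

The compounds shown carry only methyl or hydrogen on this ring, so it remains open how an ethyl group, a methoxy group, a chlorine atom or an amine would read at the same place. On these data alone, whether the direction holds on a third core, or at other concentrations, also remains open.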